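The source may report more compounds than this note shows. Statements on the series, on what has been measured and on what is new or still open speak of the compounds shown alone.

Compound 1 `O=C1Nc2ccc(OC(F)(F)F)cc2/C1=N/NC(=S)Nc1ccccc1` gives > 25000 nM, a limit of the assay.
Compound 2 `Cc1cccc(NC(=O)N/N=C2\C(=O)Nc3ccccc32)c1` gives > 25000 nM, likewise a limit.
Compound 3 `O=C1Nc2ccccc2/C1=N/NC(=S)Nc1ccc(-n2cccn2)cc1` gives > 25000 nM, again a limit.

For the measured compounds named here, these three compounds were tested in an ADME assay on RD cells (Homo sapiens) for cytotoxicity (a lower number here means that less compound is tolerated, a higher number that more compound is tolerated), and none of them gave a number: each reached (the limit of > 25000 nM in this assay, at which 3 of the 3 values shown sit), so the assay reports only that the compounds are tolerated at least up to its ceiling. Compound 1 therefore stands at the same point as the other two, and no order among them can be read from these values.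

The unmeasured compound 4 `Cc1ccc2c(c1)/C(=N/NC(=S)Nc1ccccc1)C(=O)N2` keeps the core of compound 1 and alters one substituent: methyl in place of trifluoromethoxy on an aromatic carbon. Going by the values given here, no step between two measured compounds is available in this assay, so the size of the step cannot be taken from data. The expectation is that the change leaves compound 4 at the same position as compound 1, with no shift beyond the scatter, in this assay. Compound 4 is thus estimated at 30000 nM, with a likely range from 10000 nM to 100000 nM. This estimate means an expected step that the limit leaves unreadable from compound 1 to compound 4, most likely ending again at the limit rather than a number.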

Compound 4, half-maximal cytotoxic concentration: > 25000 nM
Compound 4 gave a limit, no number; the forecaster's own chance of this, stated with the estimate: 85%; the middle value lies beyond the limit too.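

No size can be read for the change from compound 1 to compound 4, because both results stop at the same limit of the assay: the limit of > 25000 nM in this assay, at which 4 of the 4 values shown sit. As far as these compounds go, what stays open is the concentration at which any of these four compounds would harm the cells, and whether methyl in place of trifluoromethoxy alters it.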